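The source may report more compounds than this note shows. Statements on the series, on what has been measured and on what is new or still open speak of the compounds shown alone.

Measured so far:
- compound 1, `O=C(Nc1cccc(-c2oc3cc(-c4ccc(F)cc4)ccc3c(=O)c2O)c1)c1ccc(F)cc1`: 14200 nM
- compound 2, `CCc1ccc(C(=O)Nc2cccc(-c3oc4cc(-c5ccc(F)cc5)ccc4c(=O)c3O)c2)cc1`: 13200 nM
- compound 3, `COc1cc(OC)cc(C(=O)Nc2cccc(-c3oc4cc(-c5ccc(F)cc5)ccc4c(=O)c3O)c2)c1`: 6250 nM

These three compounds share one core and differ only in the group carried by the amide. In a functional assay on HCC1937 cells (Homo sapiens) for antiproliferative activity, read by CCK-8 assay, with a stated time of 72 h (on this read-out lower numbers stand for stronger inhibition and higher numbers for weaker inhibition), compound 1 gives the highest of the three numbers, though the number for compound 2 lies within the scatter of it, so no order between those two can be claimed; compound 3 is the only one set apart, by a 2.3-fold lower number from compound 1 to compound 3 (0.36 log units; beyond the scatter).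

Compound 4, `O=C(Nc1cccc(-c2oc3cc(-c4ccc(F)cc4)ccc3c(=O)c2O)c1)c1ccc([N+](=O)[O-])cc1`, is compound 1 with nitro in place of fluoro on an aromatic carbon. The step that bears most directly on it is a 1.1-fold lower number from compound 1 to compound 2 (0.03 log units; within the scatter), which also exchanged the fluoro on an aromatic carbon for another group and moved the number hardly at all. The steps of a 2.3-fold lower number from compound 1 to compound 3 (0.36 log units; beyond the scatter) and a 2.1-fold lower number from compound 2 to compound 3 (0.32 log units; beyond the scatter) show that a different ring can lower the number modestly, but a nitro group has not been tried among these compounds. The expectation for this assay is therefore a step of a 1.3-fold lower number from compound 1 to compound 4 (0.11 log units; within the scatter), little beyond the scatter, and compound 4 is estimated at 11000 nM, within a range of 4500 nM to 27000 nM.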

Compound 4, half-maximal inhibitory concentration: 5640 nM
For compound 4 the middle estimate is 2.0-fold (0.29 log units) above the measured one, within the range that was stated.
By their numbers in this assay, from the lowest: compounds 4 and 3 (each within the scatter of the next); then compounds 2 and 1 (each within the scatter of the next).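

In this assay the change from 4-fluorophenyl to 4-nitrophenyl gives a 2.5-fold lower number from compound 1 to compound 4 (0.40 log units; beyond the scatter) and thus moves the number beyond the scatter, which the exchange of fluoro for ethyl at the same place did not do. The nitro and ethyl groups also differ clearly at this place, with a 2.3-fold lower number from compound 2 to compound 4 (0.37 log units; beyond the scatter) as their step, whereas a 1.1-fold lower number from compound 3 to compound 4 (0.04 log units; within the scatter) leaves no order between the 4-nitrophenyl and 3,5-dimethoxyphenyl amides, so two quite different groups on the carbonyl carbon reach the same level. No measurement available here explains why the nitro group differs from fluoro or ethyl.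

Still open, on these data alone, is whether an amine, a carboxylic acid or a nitrile at this same place would lower the number further. As far as these compounds go, it is also open whether nitro would give a similar step at another carbon of this ring.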